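The source may report more compounds than this note shows. Statements on the series, on what has been measured and on what is new or still open speak of the compounds shown alone.

Measured so far:
- compound 1 `CC(=O)N1CCC(c2cnc(NCc3c(F)ccc4c3CCO4)c3cn[nH]c(=O)c23)CC1`: 2.9
- compound 2 `CN(C(=O)c1ccccc1)c1cnc(NCc2c(F)ccc3c2CCO3)n2cnnc12`: 2.4

Both values come from a physicochemical assay for lipophilicity, using the shake flask method, in phosphate buffer, measured as octanol-water partition, with a stated time of 30 min, at pH 7.4; a lower number here means a more polar compound, a higher number a more lipophilic compound. Compound 1 stands highest of the two numbers; compound 2 is the nearest, with a value lower by an amount beyond the usual scatter. For the measured compounds named here, no pair of these two compounds differs in only one place, so the gap between them cannot be tied to a single change and is noted only as what the two values show.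

The step of interest goes from compound 1 to compound 3 `CN(c1ccn(C)n1)c1cnc(NCc2c(F)ccc3c2CCO3)c2cn[nH]c(=O)c12`, which has not yet been run in this assay. The change is methyl(1-methyl-1H-pyrazol-3-yl)amino in place of 1-acetylpiperidin-4-yl on an aromatic carbon. A group with one hydrogen-bond acceptor and a six-membered non-aromatic ring leaves, and a group with three hydrogen-bond acceptors and a five-membered aromatic ring enters, at the same aromatic carbon of the shared core.

Going by the values given here, no single-point step gives a direct precedent for this exchange. For compound 3 the expected step is a number 0.20 log units lower from compound 1 to compound 3 (within the scatter), a small shift downward that is not expected to exceed the scatter. Compound 3 is therefore estimated at 2.7, with a range from 2.1 to 3.3.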

Compound 3, distribution coefficient: 2.4
Compound 3: the middle estimate sits 0.30 log units above what was measured; low and high end bracket the measured number.
By their numbers in this assay, from the lowest: compounds 2 and 3 (each within the scatter of the next); then compound 1.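

In this assay, for the compounds shown here, the exchange of 1-acetylpiperidin-4-yl for methyl(1-methyl-1H-pyrazol-3-yl)amino on this aromatic carbon gives a number 0.50 log units lower from compound 1 to compound 3 (beyond the scatter) and is the first step that differs in one place, so the position now has a reading of its own. The read-out therefore responds to what sits on this carbon, even though both groups carry no net charge and no hydrogen-bond donors. The exchange alters several things at once, including the ring size, the aromatic character of the ring, the hydrogen-bond acceptor count and the loss of the double bond outside aromatic rings, and no measured information on either group bears on the step.

Which of these differences carries the step stays open, as the single exchange cannot separate them. Also open, going by these compounds, is how a piperidin-4-yl without the acetyl, or a plain dimethylamino group, would stand in this assay at this aromatic carbon of the shared core.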